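Chlorine walk on the aryl ring of a pyrrolidine acid

The source may hold more compounds than are shown below. What is called first, only, known or untested is meant among the compounds shown, and "the series" means these compounds.

Measured compounds:
compound 1 `O=C(O)C1CCN(c2ccccc2)C1`: 48000 nM
compound 2 `O=C(O)C1CCN(c2ccccc2Cl)C1`: 19000 nM
compound 3 `O=C(O)C1CCN(c2ccc(Cl)c(Cl)c2)C1`: 1200 nM

The three measured compounds share a pyrrolidine carboxylic acid core carrying an aryl group on the ring nitrogen, and they differ only in the chlorine pattern on that aryl group. In an assay on cells for inhibition of Palmitoleoyl-protein carboxylesterase NOTUM variant C330S (Homo sapiens), read by fluorescence, with a stated time of 40 min (on this read-out lower numbers stand for stronger inhibition and higher numbers for weaker inhibition), compound 1 gives 48000 nM. Compound 2, which differs by chloro in place of hydrogen on an aromatic carbon, gives 19000 nM; the step of a 2.5-fold lower number from compound 1 to compound 2 (0.40 log units; beyond the scatter). Compound 3 gives 1200 nM, the lowest of the three numbers and a step beyond the scatter from either of the others. How the core of compound 3 differs from that of compound 1 is not broken down here.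

Compound 4 `O=C(O)C1CCN(c2ccc(Cl)c(Cl)c2Cl)C1` has not yet been measured. It differs from compound 3 by chloro in place of hydrogen on an aromatic carbon. Going by the values given here, this is the same kind of change as the one from compound 1 to compound 2, though the surroundings differ: in compound 4 the entering chloro sits ortho to a chloro group and meta to a chloro group as well as ortho to the group of 8 heavy atoms, whereas in compound 2 it sits only ortho to the group of 8 heavy atoms.

In this assay compound 4 is expected to show a step of a 2.0-fold lower number from compound 3 to compound 4 (0.30 log units; within the scatter), resting on the earlier step of a 2.5-fold lower number from compound 1 to compound 2 (0.40 log units; beyond the scatter), which was modest but beyond the scatter. The estimate for compound 4 is 600 nM, with a likely range from 200 nM to 2000 nM.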

Compound 4, half-maximal inhibitory concentration: 600 nM
Estimate against measurement, compound 4: no gap at the digits printed, and the stated range covers the measured number.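

In this assay, chloro in place of hydrogen on the core of compound 3 gives a 2.0-fold lower number from compound 3 to compound 4 (0.30 log units; within the scatter), so this step alone does not separate the two compounds. Set beside the earlier step, the change gives steps of similar size on the two cores, with no difference that can be told apart: the same change on two cores in this assay, a 2.5-fold lower number (0.40 log units; beyond the scatter) from compound 1 to compound 2 and a 2.0-fold lower number (0.30 log units; within the scatter) from compound 3 to compound 4, 1.3-fold (0.10 log units) apart, within the scatter of two such steps This shows that the step seen on the core of compound 1 is compatible with the one on the core of compound 3, even though the entering chloro in compound 4 sits ortho to a chloro group and meta to a chloro group as well as ortho to the group of 8 heavy atoms, but it does not show a gain on the second core that stands clear of the scatter, nor does one pair of steps on two cores make a rule for the wider series.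

The compounds shown carry only chloro or hydrogen on the aromatic ring, which leaves open whether fluoro, methyl or methoxy on the same aromatic carbon would give a step of like size. They also leave open whether the steps would hold with an amide or a tetrazole in place of the carboxylic acid.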